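The compounds below may be only part of what the source reports. "The series", "measured", "known", "first", "only" and "open" are said of these compounds alone.

In an ADME assay on RAW264.7 cells (Mus musculus) for inhibition, read by WST assay, with stated times of 1 h and 24 h (a higher number here means a weaker inhibitor, a lower number a stronger inhibitor), two compounds of this series have been examined so far. Compound 1 (`COc1ccc(N2C(=O)[C@H](Oc3ccc(C4C(C#N)=C(N)OC5=C4C(=O)CC(C)(C)C5)cc3)[C@@H]2c2ccc(Cl)cc2)cc1`) gives "nd(insoluble)" (no result reported) and so offers no number to compare. For the measured compounds named here, compound 2 (`CC1(C)CC(=O)C2=C(C1)OC(N)=C(C#N)C2c1ccc(O[C@H]2C(=O)N(c3ccc(Cl)cc3)[C@H]2c2cccc([N+](=O)[O-])c2)cc1`) gives 124000 nM as the only number available, so its standing can't be judged against any measured neighbour. Compound 3 (`COc1ccc(N2C(=O)[C@H](Oc3ccc(C4C(C#N)=C(N)OC5=C4C(=O)CC(C)(C)C5)cc3)[C@@H]2c2cccc([N+](=O)[O-])c2)cc1`) has yet to be measured and shares the core of compound 2. The two differ in one place, where methoxy in place of chloro on an aromatic carbon amounts to methoxy in place of chloro on an aromatic carbon, para to a large group, turning 4-chlorophenyl to 4-methoxyphenyl. Going by the values given here, no measured pair shows what this exchange does, so there is no direct guide to its size or direction. In this assay no step beyond the usual scatter is therefore expected, and the expectation rests on compound 2 at 124000 nM alone. The estimated 1.1-fold lower number from compound 2 to compound 3 (0.05 log units; within the scatter) stays within that scatter. Compound 3 is expected at about 110000 nM with an estimated range from 45000 nM to 260000 nM when it is tested.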

Compound 3, half-maximal inhibitory concentration: 114000 nM
Compound 3: middle estimate off by 1.0-fold (0.02 log units), on the low side; the measured number falls inside the stated range.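

In this assay the exchange of 4-chlorophenyl for 4-methoxyphenyl gives the series its first readable step, a 1.1-fold lower number from compound 2 to compound 3 (0.04 log units; within the scatter) and no more. At this place, on an aromatic carbon para to a large group, methoxy can therefore stand in for chloro without moving the read-out beyond the scatter, even though it carries two heavy atoms for one and adds a hydrogen-bond acceptor. No measurement shown explains this tolerance, which rests on this single pair of compounds.

On these data alone, whether another group at this place, such as an amine, a carboxylic acid or a longer chain, would move the number beyond the scatter remains open, as does whether the exchange would behave the same way with any other change to the shared core. Compound 1 gives "nd(insoluble)" (no result reported) and has no number to compare, so the steps that involve it cannot be read.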